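The source may report more compounds than this note shows. Statements on the series, on what has been measured and on what is new or still open speak of the compounds shown alone.

In a functional assay on HeLa cells (Homo sapiens) for cytotoxicity, read by MTT assay, with a stated time of 48 h (on this read-out higher numbers stand for weaker inhibition and lower numbers for stronger inhibition), compound 1 `O=C(O)CN1C(=O)/C(=C/c2nc3ccccc3n2Cc2ccc([N+](=O)[O-])cc2)SC1=S` gives 18600 nM and compound 3 `O=C(O)CN1C(=O)/C(=C/c2nc3ccccc3n2Cc2ccc(F)cc2F)SC1=S` gives 26100 nM. Among the compounds with values here, these two sit together at the upper end of the numbers so far. Compound 2 `Cc1ccc(Cn2c(/C=C3\SC(=S)N(CC(=O)O)C3=O)nc3ccccc32)cc1`, at 1280 nM, stands clear of both, with a 20-fold higher number from compound 2 to compound 3 (1.31 log units; beyond the scatter).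

The next step leads to compound 4 `O=C(O)CN1C(=O)/C(=C/c2nc3ccccc3n2Cc2cccc(F)c2)SC1=S`, not yet measured: 3-fluorophenyl in place of 4-nitrophenyl on a saturated chain carbon bound to an aromatic nitrogen. In words, this is 3-fluorophenyl in place of 4-nitrophenyl on a saturated chain carbon bound to an aromatic nitrogen.

Within the data shown here, two measured steps bear on it. Nearest in kind is the change to the 2,4-difluorophenyl of compound 3, which gave a 1.4-fold higher number from compound 1 to compound 3 (0.15 log units; within the scatter). The change to the 4-methylphenyl of compound 2 shows that leaving the 4-nitrophenyl can matter far more, with a 15-fold lower number from compound 1 to compound 2 (1.16 log units; beyond the scatter). Among the measured compounds shown here, no measured compound carries the 3-fluorophenyl itself, so the evidence is thin and the range must stay wide.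

The fluorinated comparison carries more weight, and the result for compound 2 tilts the expectation slightly downward in this assay. The estimated step is a 1.7-fold lower number from compound 1 to compound 4 (0.23 log units; within the scatter), a modest move towards a lower number. For compound 4 the expected value is 11000 nM, with an estimated range of 3000 nM to 30000 nM.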

Compound 4, half-maximal inhibitory concentration: > 50000 nM
Compound 4 gave a limit, no number; the forecaster's own chance of this, stated with the estimate: 3%; middle value at least 4.5-fold (0.65 log units) away from the limit.
By their numbers in this assay, from the lowest: compound 2; then compounds 1 and 3 (each within the scatter of the next). At a limit, above all of these: compound 4.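

Compound 4 gives a limit of the assay and not a number: the limit of > 50000 nM in this assay, at which 1 of the 4 values shown sits. This shows that the group on a saturated chain carbon bound to an aromatic nitrogen can also move the number upward from compound 1, since 3-fluorophenyl in place of 4-nitrophenyl gives an at least 2.6-fold higher number from compound 1 to compound 4 (0.42 log units; beyond the scatter), whereas the earlier replacements gave only a step within the scatter or a step downward. The fluorinated compound 4 also lies far from the 4-methylphenyl compound, with an at least 39-fold higher number from compound 2 to compound 4 (1.59 log units; beyond the scatter), while the step from the 2,4-difluorophenyl, an at least 1.9-fold higher number from compound 3 to compound 4 (0.28 log units; that floor lies within the scatter), has a floor too small to separate compound 4 from compound 3.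

On these data alone, how far compound 4 lies beyond its limit remains open, and so does the order of compounds 3 and 4. Also open, as far as these compounds go, is whether the low number of compound 2 depends on the methyl group or on where it sits on the ring, a question that 3-methylphenyl and 4-fluorophenyl on the same carbon would address.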